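The source may report more compounds than this note shows. Statements on the series, on what has been measured and on what is new or still open speak of the compounds shown alone.

Compound 1 `Oc1ccc(-c2cc(-c3cccc(O)c3)nc(-c3cccc(O)c3)c2)cc1` gives 2230 nM in a functional assay on T47D cells (Homo sapiens) for cytotoxicity, read by CCK-8 assay, with a stated time of 4 days; a lower number here means a stronger inhibitor, a higher number a weaker inhibitor.
Compound 2 `Oc1ccc(-c2cc(-c3ccccc3O)nc(-c3ccccc3O)c2)cc1` gives 18300 nM in this assay.

Compound 2 has the higher of the two numbers in this assay; compound 1 sits below it by a gap beyond the usual scatter, so compound 2 is the weaker inhibitor of the two measured. Compound 3 `Oc1ccc(-c2cc(-c3cccc(O)c3)nc(-c3ccccc3O)c2)cc1` has not yet been measured. It differs from compound 2 in one place: 3-hydroxyphenyl in place of 2-hydroxyphenyl on an aromatic carbon. This takes compound 3 partway toward compound 1, which carries two 3-hydroxyphenyl groups where compound 2 carries two 2-hydroxyphenyl groups; compound 3 carries one of each. Going by the values given here, no single measured step of this kind exists, so the expectation rests on compound 1 and compound 2 alone. Compound 3 is expected to fall between them, with a step toward a lower number of about a 2.9-fold lower number from compound 2 to compound 3 (0.46 log units; beyond the scatter), beyond the scatter. Compound 3 is therefore estimated at 6400 nM, within a range of 2500 nM to 16000 nM.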

Compound 3, half-maximal inhibitory concentration: 4810 nM
For compound 3 the middle estimate is 1.3-fold (0.12 log units) above the measured one, and the stated range covers the measured number.
By their numbers in this assay, from the lowest: compound 1; then compound 3; then compound 2.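

In this assay, the exchange on an aromatic carbon next to the ring nitrogen can now be read one group at a time: 3-hydroxyphenyl in place of 2-hydroxyphenyl gives a 3.8-fold lower number from compound 2 to compound 3 (0.58 log units; beyond the scatter). Starting from the other side, 2-hydroxyphenyl in place of 3-hydroxyphenyl gives a 2.2-fold higher number from compound 1 to compound 3 (0.33 log units; beyond the scatter), so a single exchange is enough to shift the number in either setting, and in both the 3-hydroxyphenyl group goes with the lower number. Nothing in the data shown explains why the two groups differ.

The compounds shown all keep a hydroxyl group on each outer ring, so it remains open how this position would respond to a methoxy group, an amine or a carboxylic acid in its place. Also open, going by these compounds, is whether moving the 4-hydroxyphenyl group's hydroxyl would shift the number in the same way.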